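The source may report more compounds than this note shows. Statements on the series, on what has been measured and on what is new or still open speak of the compounds shown alone.

Measured compounds:
Compound 1, `O=C(NCCCCc1ccccc1)n1c(=O)oc2cc(C3CCCCC3)ccc21`: 89 nM
Compound 2, `CN1CCN(c2ccc3c(c2)oc(=O)n3C(=O)NCCCCc2ccccc2)CC1=O`: 92 nM

In an assay on HEK293 cells for inhibition of acid ceramidase (Homo sapiens), read by fluorescence, with stated times of 10 min and 3 h (on this read-out lower numbers stand for stronger inhibition and higher numbers for weaker inhibition), compound 2 gives 92 nM. Going by the values given here, its only neighbour is compound 1, which gives 89 nM in this assay, and the step of a 1.0-fold higher number from compound 1 to compound 2 (0.01 log units; within the scatter) lies within the scatter, so the two compounds stand together rather than in any order.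

Compound 3, `CCN1CCC(c2ccc3c(c2)oc(=O)n3C(=O)NCCCCc2ccccc2)CC1`, has not been measured in this assay. It differs from compound 2 in one place: 1-ethylpiperidin-4-yl in place of 4-methyl-3-oxopiperazin-1-yl on an aromatic carbon.

Among the compounds with values here, only one measured step bears on this change, the step of a 1.0-fold higher number from compound 1 to compound 2 (0.01 log units; within the scatter), which exchanged a ring of carbon only for a ring with two hetero atoms at the same aromatic carbon without moving the number beyond the scatter. The change to compound 3 again exchanges the group at that carbon for a ring of similar size, this time with one hetero atom. On the evidence of that single step, no move beyond the scatter is expected in this assay in either direction.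

Compound 3 is therefore expected to give about 95 nM in this assay, with a range from 40 nM to 230 nM. The step this estimate implies is expected to be a 1.0-fold higher number from compound 2 to compound 3 (0.01 log units; within the scatter), within the scatter.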

Compound 3, half-maximal inhibitory concentration in the acid ceramidase assay: 92 nM
Estimate against measurement, compound 3: 1.0-fold (0.01 log units) above, within the range that was stated.
By their numbers in the acid ceramidase assay, from the lowest: compounds 1, 2 and 3 (each within the scatter of the next).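

Compound 3 shows that this aromatic carbon has now taken a third group without any shift in the acid ceramidase assay: there is no change at the digits printed from compound 2 to compound 3 (within the scatter), and there is a 1.0-fold higher number from compound 1 to compound 3 (0.01 log units; within the scatter), so cyclohexyl, 4-methyl-3-oxopiperazin-1-yl and 1-ethylpiperidin-4-yl stand together on this read-out. In a physicochemical assay for solubility, read by HPLC, in phosphate buffer, measured as kinetic solubility, with a stated time of 1 h, at pH 7.4, tested at 250 uM (a higher number here means a more soluble compound, a lower number a less soluble compound), by contrast, the exchange of 4-methyl-3-oxopiperazin-1-yl for 1-ethylpiperidin-4-yl goes with much higher solubility, so a change that is silent for inhibition is far from silent here: the measured solubility of compound 2, < 1000 nM, and of compound 3, 198000 nM, an at least 190-fold higher number (2.29 log units; beyond the scatter). In the physicochemical assay compound 3 gives 198000 nM as a measured number. In the physicochemical assay compound 2 gives < 1000 nM, which is a limit of that assay and not a number: the limit of < 1000 nM in the physicochemical assay, at which 1 of the 2 values shown sits.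

The compounds shown give no solubility value for compound 1, so cyclohexyl cannot be set against 1-ethylpiperidin-4-yl on that read-out. They also leave open whether the ring nitrogen of 1-ethylpiperidin-4-yl is what matters, which a piperidine with a different group on that nitrogen, or an open-chain amine such as dimethylaminomethyl at the same carbon, could test in both assays.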